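The compounds below may be only part of what the source reports. "The series", "measured", "known", "first", "only" and "open" are said of these compounds alone.

Measured compounds:
compound 1, `Cc1cccc(Oc2ccnc(N3CCC[C@H]3C(=O)NCc3cccnc3)n2)c1`, 5%
compound 2, `COC[C@@H]1CCCN1C(=O)C1CCCN1c1cc(Nc2cccc(Br)c2)ncn1`, 5%

Both compounds were tested in an assay on isolated protein for inhibition of tyrosine-protein kinase Fes/Fps (Homo sapiens), read by HTRF, tested at 10 uM; on this read-out lower numbers stand for less inhibition and higher numbers for more inhibition at the one concentration tested (going by the name of the read-out). Compound 1 gives 5%, and compound 2 gives 5%; the two values stand level at the digits shown, within the usual scatter, so neither can be set above the other. Compound 1 thus sits at the low end of the read-out on the numbers at hand.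

The unmeasured compound 3, `Cc1cccc(Oc2ccnc(N3CCC[C@H]3C(=O)NCCCn3ccnc3)n2)c1`, keeps the core of compound 1 and alters the group on the amide-type nitrogen: 2-(1H-imidazol-1-yl)ethyl in place of pyridin-3-yl on a saturated chain carbon bound to an amide-type nitrogen. Within the data shown here, no measured pair shows a change of this kind, so the step has to be expected from the values alone. The low level is expected to carry over because compound 1 gives 5% and compound 2 the same at the digits shown. For compound 3 no step beyond the scatter is expected in this assay in either direction: no change at the digits printed from compound 1 to compound 3 (within the scatter). Compound 3 is estimated at 5%, with a range from 0% to 15%.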

Compound 3, a percentage reported as inhibition, at one concentration (the size of the read-out at that concentration, not a potency): 2%
Estimate against measurement, compound 3: 3 percentage points above; measured number inside the range.
By their numbers in this assay, from the lowest: compounds 3, 1 and 2 (each within the scatter of the next).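

In this assay, 2-(1H-imidazol-1-yl)ethyl in place of pyridin-3-yl on a saturated chain carbon bound to an amide-type nitrogen gives a number 3 percentage points lower from compound 1 to compound 3 (within the scatter). Among these compounds, this is the first measured pair at this position, and it shows that exchanging the six-membered aromatic ring with 1 hetero atom for a five-membered aromatic ring with 2 hetero atoms, with the chain change that comes with it, produces no step beyond the scatter. No supporting data bear on this outcome.

On these data alone, it remains open whether this position can move the read-out at all with a non-aromatic end group, such as a carboxylic acid or a morpholine on the chain. Also open, as far as these compounds go, is whether a change elsewhere on the core of compound 1, such as a chlorine on the methylphenoxy ring, would lift the read-out from this low level.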